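The source may report more compounds than this note shows. Statements on the series, on what has been measured and on what is new or still open speak of the compounds shown alone.

Measured compounds:
Compound 1 `CC(c1cc2cccnc2cc1F)n1cnc2ncc(-c3cnn(C)c3)nc21` gives 9 uL/min in an ADME assay on microsomes from liver (Homo sapiens) for metabolic stability, read by LC-MS, using NADPH, with stated times of 5 min and 30 min, tested at 1 uM; on this read-out lower numbers stand for slow clearance and higher numbers for fast clearance.
Compound 2 `CC(c1c(F)cc2ncccc2c1F)n1cnc2ncc(-c3cnn(CCO)c3)nc21` gives 2 uL/min in this assay.
Compound 3 `COC(=O)c1ccc(-c2cnc3ncn(C(C)c4cc5cccnc5cc4F)c3n2)cc1F` gives 73 uL/min in this assay.

Compound 2 has the lowest of the three numbers in this assay; compound 1 lies above it beyond the scatter, and compound 3 lies furthest above it. Compound 4 `CC(c1c(F)cc2ncccc2c1F)n1cnc2ncc(-c3cnc4ccccc4c3)nc21` has not yet been measured. It differs from compound 2 in one place: quinolin-3-yl in place of 1-(2-hydroxyethyl)-1H-pyrazol-4-yl on an aromatic carbon.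

For the measured compounds named here, one measured step bears on this change, since it also swaps the aryl group on the same aromatic carbon of the shared core: an 8.1-fold higher number from compound 1 to compound 3 (0.91 log units; beyond the scatter). That step raised the number clearly. Going by the values given here, with only one such step, and a different entering group here, the size is uncertain, but an increase is the more likely direction. Compound 4 is therefore expected to give 15 uL/min in this assay, within a range of 4 uL/min to 55 uL/min. The expected step is a 7.5-fold higher number from compound 2 to compound 4 (0.88 log units; beyond the scatter).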

Compound 4, intrinsic clearance in a liver preparation (reported as CLH), per the amount of preparation that the assay uses: 51 uL/min
Estimate against measurement, compound 4: 3.4-fold (0.53 log units) below, and the stated range covers the measured number.
By their numbers in this assay, from the lowest: compound 2; then compound 1; then compounds 4 and 3 (each within the scatter of the next).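

In this assay the swap to quinolin-3-yl gives a 26-fold higher number from compound 2 to compound 4 (1.41 log units; beyond the scatter) and so shows a large rise at this aromatic carbon with a second entering group and on a second version of the shared core. Read beside an 8.1-fold higher number from compound 1 to compound 3 (0.91 log units; beyond the scatter) it means that both steps placing a six-membered aromatic ring where a pyrazolyl group stood raise the number, and no compound shown goes against this. Nothing measured here speaks to what lies behind the rise.

The compounds shown leave open how much of the step belongs to the loss of the 2-hydroxyethyl chain and how much to the change of ring. They also leave open whether an amine or a carboxylic acid on the quinolin-3-yl would bring the number back down.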